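The source may report more compounds than this note shows. Statements on the series, on what has been measured and on what is new or still open speak of the compounds shown alone.

Measured compounds:
- compound 2 `N#C[C@@H]1CCCN1C(=O)[C@@H]1C[C@H](C(=O)N2CCCCC2)CN1` — 50%
- compound 3 `N#C[C@@H]1CCCN1C(=O)[C@@H]1C[C@H](C(N)=O)CN1` — 20%
- compound 1 `N#C[C@@H]1CCCN1C(=O)[C@@H]1C[C@H](C(=O)N2CCCCCCC2)CN1` — "not determined" (no result reported)

In an assay on the whole organism (plasma, strain Sprague-Dawley) for inhibition of Dipeptidyl peptidase 4 (Rattus norvegicus), with a stated time of 10 h, at a dose of 1 mg/kg by the oral route (on this read-out higher numbers stand for more inhibition at the one dose given (going by the name of the read-out) and lower numbers for less inhibition), compound 3 stands lowest of the two numbers available; compound 2 gives 50% and the step of a number 30 percentage points lower from compound 2 to compound 3 (beyond the scatter) lies beyond the scatter. Compound 1 gives no number in this assay.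

Compound 4 `CN(C)C(=O)[C@@H]1CN[C@H](C(=O)N2CCC[C@H]2C#N)C1` differs from compound 3 as follows: dimethylamino in place of amino on a carbonyl carbon. Among the measured compounds shown here, the only step that bears on it is the one from the larger amine to amino, a number 30 percentage points lower from compound 2 to compound 3 (beyond the scatter); the change to dimethylamino runs the other way but stops short of the ring amine of compound 2, so a rise smaller than that step is expected, possibly within the scatter. Compound 4 is estimated at 35%, range 15% to 55%, an expected step of a number 15 percentage points higher from compound 3 to compound 4 (beyond the scatter).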

Compound 4, a percentage reported as inhibition, in the whole organism at one dose (the size of the read-out at that dose, not a potency): 52%
For compound 4 the middle estimate is 17 percentage points below the measured one; low and high end bracket the measured number.
By their numbers in this assay, from the lowest: compound 3; then compounds 2 and 4 (each within the scatter of the next).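

In this assay, dimethylamino in place of amino on a carbonyl carbon gives a number 32 percentage points higher from compound 3 to compound 4 (beyond the scatter), so a ring on this amide is not required for the higher number. Set against piperidin-1-yl, the change reads a number 2 percentage points higher from compound 2 to compound 4 (within the scatter), and the two groups cannot be told apart at this position. Nothing available explains the result.

Still open, as far as these compounds go, is how a methylamino or morpholin-4-yl group on this carbonyl carbon would read, and how a carboxylic acid in place of the amide would compare.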